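The source may report more compounds than this note shows. Statements on the series, on what has been measured and on what is new or still open speak of the compounds shown alone.

Compound 2 `CC(C)CCn1c(CN2CCN(C(=O)C3CC3)CC2)nc2ccccc21` and compound 1 `O=C(C1CC1)N1CCN(Cc2nc3ccccc3n2Cc2ccccc2C(F)(F)F)CC1` share one core and differ only in the group on a saturated chain carbon bound to an aromatic nitrogen. Among the measured compounds shown here, in an assay on isolated protein for inhibition of aldehyde dehydrogenase 1A1 (Homo sapiens), read by spectrophotometry, tested at 10 uM (a higher number here means more inhibition at the concentration tested (going by the name of the read-out), a lower number less inhibition), compound 2 gives 70%, and compound 1 gives 56.3%, so compound 2 stands highest of the two numbers measured so far. For the measured compounds named here, the only measured step, a number 13.7 percentage points higher from compound 1 to compound 2 (beyond the scatter), put isobutyl in place of 2-(trifluoromethyl)phenyl at that place and was modest. Compound 3 `O=C(C1CC1)N1CCN(Cc2nc3ccccc3n2CC2CCCC2)CC1` differs from compound 2 by cyclopentyl in place of isobutyl on a saturated chain carbon bound to an aromatic nitrogen. Going by the values given here, that earlier step is the only one bearing on this change, since it sits at the same place; the present swap keeps a carbon-only group there, so no step beyond the scatter is expected, a number 2 percentage points lower from compound 2 to compound 3 (within the scatter). Compound 3 is therefore estimated at 68%, within a range of 50% to 84%.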

Compound 3, a percentage reported as inhibition, at one concentration (the size of the read-out at that concentration, not a potency): 44.5%
Compound 3: middle estimate off by 23.5 percentage points, on the high side; measured number outside the range, below it.
By their numbers in this assay, from the lowest: compound 3; then compound 1; then compound 2.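

This position proves more sensitive than the first pair suggested: even a swap between two groups made only of carbon shifts the result in this assay, with cyclopentyl in place of isobutyl giving a number 25.5 percentage points lower from compound 2 to compound 3 (beyond the scatter). Cyclopentyl also falls short of the 2-(trifluoromethyl)phenyl group, with a number 11.8 percentage points lower from compound 1 to compound 3 (beyond the scatter), so among these three compounds the open-chain isobutyl stands highest, the aromatic group in the middle and the saturated ring lowest. Nothing at hand explains this drop.

Among the compounds shown here, with only three groups, the effect of having a ring cannot be separated from the effect of the group's size. On these data alone, it remains open whether a longer chain such as hexyl would hold the number up, and whether a cyclohexyl ring or a ring carrying an amine would lower it further.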